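Phosphate in place of methyl on two related cores

The source may report more compounds than this note shows. Statements on the series, on what has been measured and on what is new or still open speak of the compounds shown alone.

Measured compounds:
compound 1, `COc1cc(/C=C\Cc2cc(OC)c3ccsc3c2)cc(OC)c1OC`, 8100 nM
compound 2, `COc1cc(/C=C\Cc2cc(OC)c3ccoc3c2)cc(OC)c1OC`, 7500 nM
compound 3, `COc1cc(/C=C\Cc2cc(OP(=O)(O)O)c3ccsc3c2)cc(OC)c1OC`, 640 nM

Of the compounds shown here, three have been measured in a functional assay on BMEC cells (Bos taurus) for antiproliferative activity; on this read-out lower numbers stand for stronger inhibition and higher numbers for weaker inhibition. Compound 1, with the structure shown earlier, gives 8100 nM, and compound 2 gives 7500 nM; these two numbers lie within the scatter of each other, so nothing is said about their order. The difference between the two cores of compound 1 and compound 2 is not broken down here.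

Compound 3 is reached from compound 1 by one change, (a group of 4 heavy atoms (3 oxygen, 1 phosphorus; no ring) in place of one carbon atom, on an oxygen on an aromatic ring). In this assay compound 3 gives 640 nM. The step is a 13-fold lower number from compound 1 to compound 3 (1.10 log units; beyond the scatter), a large move to a lower number.

The unmeasured compound 4, `COc1cc(/C=C\Cc2cc(OP(=O)(O)O)c3ccoc3c2)cc(OC)c1OC`, is reached from compound 2 by the same kind of change, (a group of 4 heavy atoms (3 oxygen, 1 phosphorus; no ring) in place of one carbon atom, on an oxygen on an aromatic ring); the place lines for both changes read alike, an oxygen on an aromatic ring whose other neighbour is an aromatic carbon. Because a 13-fold lower number from compound 1 to compound 3 (1.10 log units; beyond the scatter) was large and the change occurs twice in all, the expected step is a 13-fold lower number from compound 2 to compound 4 (1.10 log units; beyond the scatter), of similar size to the earlier one. For the measured compounds named here, with only one prior instance, a wider range is kept. Compound 4 is therefore estimated at 600 nM, with an expected range from 250 nM to 1500 nM.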

Compound 4, half-maximal inhibitory concentration: 340 nM
Compound 4: the middle estimate sits 1.8-fold (0.25 log units) above what was measured; measured number inside the range.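

In this assay, putting the phosphate group in place of the methyl on the oxygen on an aromatic ring gives a 22-fold lower number from compound 2 to compound 4 (1.34 log units; beyond the scatter) and so repeats on a second core what was seen on the first: the same change on two cores in this assay, a 13-fold lower number (1.10 log units; beyond the scatter) from compound 1 to compound 3 and a 22-fold lower number (1.34 log units; beyond the scatter) from compound 2 to compound 4, 1.7-fold (0.24 log units) apart, within the scatter of two such steps

The change therefore carries over between these two cores, with both steps large, both going to a lower number and the two sizes not distinguishable from each other. This is a result for two cores in one read-out, so it supports transfer between this pair and does not establish a rule for the series or for any other core. Nor does the agreement show what about the entering group produces the step, since the compounds give only its size and direction.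

The compounds shown leave open how other groups on that oxygen, such as an amine, a carboxylic acid or a longer chain, would compare with the methyl and the phosphate group on either core. They also leave open whether the same change would give a step of similar size at another oxygen on these compounds, where the surroundings may not read alike.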